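The compounds below may be only part of what the source reports. "The series", "measured", "known", "first", "only" and "open" are said of these compounds alone.

For the measured compounds named here, compound 1 `Nc1scc(CN2CCN(c3ccccc3F)CC2)c1C(=O)c1ccc(Cl)cc1` gives -1% in a functional assay on CHO cells with adenosine receptor A1 (Homo sapiens) as the target, read by cAMP accumulation and immunoassay, with a stated time of 6 min, tested at 0.1 uM (on this read-out lower numbers stand for a stronger effect and higher numbers for a weaker effect at the one concentration tested), and compound 2 `Nc1scc(CN2CCN(c3cc(F)ccc3F)CC2)c1C(=O)c1ccc(Cl)cc1` gives -13% in this assay, the lowest of the two numbers measured so far. Compound 3 `Nc1scc(CN2CCN(c3c(F)cc(F)cc3F)CC2)c1C(=O)c1ccc(Cl)cc1` differs from compound 2 by 2,4,6-trifluorophenyl in place of 2,5-difluorophenyl on an amine nitrogen in a ring. Going by the values given here, the only measured step that bears on this change is a number 12 percentage points lower from compound 1 to compound 2 (beyond the scatter), which was modest yet beyond the scatter. On that basis a further small lowering, or none beyond the scatter, is expected in this assay, that is a number 5 percentage points lower from compound 2 to compound 3 (within the scatter). Compound 3 is therefore expected to give -18%, with a range from -35% to 0%.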

Compound 3, a percentage reported as activity, at one concentration (the size of the read-out at that concentration, not a potency): -3.9%
Beside the measured number, compound 3's estimate is 14.1 percentage points below it, and the stated range covers the measured number.
By their numbers in this assay, from the lowest: compounds 2, 3 and 1 (each within the scatter of the next, the first and the last beyond it).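

In this assay the 2,4,6-trifluorophenyl group gives a number 9.1 percentage points higher from compound 2 to compound 3 (within the scatter) and a number 2.9 percentage points lower from compound 1 to compound 3 (within the scatter), so compound 3 cannot be told apart from compound 2 or compound 1, although those two lie beyond the scatter of each other. The step of a number 12 percentage points lower from compound 1 to compound 2 (beyond the scatter) therefore does not extend into a trend with the count of fluorines on this ring, and compound 3 goes against such a trend. No evidence is available that accounts for this result. As far as these compounds go, what a chlorine, a methoxy group or a pyridine ring at this place would give remains open.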